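The compounds below may be only part of what the source reports. "The series", "measured", "known", "first", "only" and "open" are said of these compounds alone.

In a functional assay on DU-145 cells (Homo sapiens) for inhibition, read by trypan blue exclusion, with a stated time of 96 h (a higher number here means a weaker inhibitor of growth, a lower number a stronger inhibitor of growth), compound 3 `O=C(/C(=C\c1c(O)cc(O)cc1O)Sc1ccc(Br)cc1)c1ccc(Cl)cc1` gives 50000 nM. Among the compounds with values here, that is level with compound 1 `O=C(/C(=C\c1ccc(O)cc1O)Sc1ccc(Br)cc1)c1ccc(Cl)cc1` at 50000 nM, and these two share the highest number so far. Compound 2 `O=C(/C(=C\c1ccc(Br)cc1)SCc1ccc(Cl)cc1)c1ccc(Cl)cc1` gives 1000 nM, a much lower number than either of them.

The next compound, compound 4 `O=C(/C(=C\c1ccc(Br)cc1)Sc1ccc(Br)cc1)c1ccc(Cl)cc1`, makes one change to compound 3: 4-bromophenyl in place of 2,4,6-trihydroxyphenyl on a double-bonded chain carbon bound to a double-bonded chain carbon. In other words, 4-bromophenyl takes the place of 2,4,6-trihydroxyphenyl on a double-bonded chain carbon bound to a double-bonded chain carbon.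

Within the data shown here, only one measured step touches this part of the molecule, a single hydroxy in place of hydrogen on an aromatic carbon: no change at the digits printed from compound 1 to compound 3 (within the scatter). That step says little here, since it leaves hydroxy groups on both compounds, whereas compound 4 has none on this ring. The closer hint comes from compound 2, which carries the same 4-bromophenyl and gives 1000 nM, although it also differs from compound 4 elsewhere. With so few data, a clear move to a lower number is expected, but probably not all the way down to compound 2. The estimated step is a 10-fold lower number from compound 3 to compound 4 (1.00 log units; beyond the scatter). Compound 4 is expected to give about 5000 nM, with an estimated range of 800 nM to 30000 nM.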

Compound 4, concentration for 50% growth inhibition: 1000 nM
Beside the measured number, compound 4's estimate is 5.0-fold (0.70 log units) above it; the measured number falls inside the stated range.
By their numbers in this assay, from the lowest: compounds 2 and 4 (each within the scatter of the next); then compounds 1 and 3 (each within the scatter of the next).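

At the double-bonded chain carbon bound to a double-bonded chain carbon, the ring matters a great deal in this assay: replacing 2,4,6-trihydroxyphenyl with 4-bromophenyl gives a 50-fold lower number from compound 3 to compound 4 (1.70 log units; beyond the scatter), and replacing 2,4-dihydroxyphenyl with 4-bromophenyl gives a 50-fold lower number from compound 1 to compound 4 (1.70 log units; beyond the scatter), whereas the earlier step between two hydroxylated rings showed no such shift. On the sulfur, by contrast, 4-bromophenyl in place of 4-chlorobenzyl gives no change at the digits printed from compound 2 to compound 4 (within the scatter), so this pair of compounds shows that swap to be far less telling than the change of ring at the chain carbon. Nothing measured here accounts for the large drop in the number.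

The swap removes the hydroxy groups and adds a bromine in one move, so their separate contributions cannot be told apart; an unsubstituted phenyl or a 4-methoxyphenyl at the chain carbon would help to separate them. Also open, on these data alone, is how a ring carrying an amine or a carboxylic acid would behave there, and whether the result on the sulfur would hold for a longer chain.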